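Exchanging Phenyl for 2-Oxocyclohexyl on the Ring Nitrogen

The source may report more compounds than this note shows. Statements on the series, on what has been measured and on what is new or still open speak of the compounds shown alone.

Measured compounds:
compound 1 `O=C1C[C@H](OCc2cn(-c3ccccc3)nn2)[C@H]2CO[C@@H]1O2` — 25200 nM
compound 2 `O=C1C[C@H](OCc2cn(-c3cccc4ccccc34)nn2)[C@H]2CO[C@@H]1O2` — 21900 nM

Of the compounds shown here, two sharing the same core have been tested so far. In a functional assay on MDA-MB-231 cells (Homo sapiens) for cytotoxicity, read by MTT assay, with a stated time of 48 h (a lower number here means a stronger inhibitor, a higher number a weaker inhibitor), compound 1 gives 25200 nM, the highest of the two numbers recorded. Compound 2 gives 21900 nM in this assay, and the gap between the two lies within the usual scatter, so neither can be said to inhibit more strongly than the other; both are weak inhibitors on this scale.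

The next compound, compound 3 `O=C1CCCCC1n1cc(CO[C@H]2CC(=O)[C@@H]3OC[C@H]2O3)nn1`, keeps the shared core and differs from compound 1 only in one place: 2-oxocyclohexyl in place of phenyl on an aromatic nitrogen. Within the data shown here, no pair of measured compounds differs in one place, so there is no precedent within this set for the size of such a step, and the analyst can lean only on the two numbers above, which are close to each other despite their different aromatic groups on that ring nitrogen.

On that basis the analyst expects the step of a 1.0-fold lower number from compound 1 to compound 3 (0.00 log units; within the scatter) to stay within the scatter, in no particular direction. Compound 3 is therefore estimated at 25000 nM in this assay, with a likely range from 8000 nM to 80000 nM.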

Compound 3, half-maximal inhibitory concentration: 36000 nM
Compound 3: middle estimate off by 1.4-fold (0.16 log units), on the low side; measured number inside the range.
By their numbers in this assay, from the lowest: compounds 2, 1 and 3 (each within the scatter of the next).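

In this assay, putting 2-oxocyclohexyl in place of phenyl on the aromatic nitrogen gives a 1.4-fold higher number from compound 1 to compound 3 (0.15 log units; within the scatter), the first step measured at this position. The earlier compounds shown here carried only aromatic groups on this nitrogen, whereas compound 3 shows that a six-membered non-aromatic ring of carbon only, bearing a carbonyl and so adding one hydrogen-bond acceptor, can stand there with a number that remains within the scatter of that of compound 1. No measurement offered here accounts for this result, so the step can be described only by its size.

The compounds shown leave open whether any group on this nitrogen can move the number beyond the scatter of compound 1 in either direction. It also remains to be seen whether a plain cyclohexyl ring without the carbonyl, a longer alkyl chain such as hexyl, or a phenyl ring carrying an amine or a carboxylic acid would give a clearly different number.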